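A few compounds are considered here, and "the series" means these few. Any claim that something is new, unique, unknown or untested is made for them only; others in the source may bear on it.

Working notes on the acyl sulfamate series. For the measured compounds named here, compound 1 `CC(C)C[C@H](O)C(=O)NS(=O)(=O)OC[C@H]1O[C@@H](n2cnc3c(N)ncnc32)[C@H](O)[C@@H]1O` is the reference point: in a functional assay on SNU-638 cells (Homo sapiens) for antiproliferative activity, read by sulforhodamine B assay, with a stated time of 72 h (on this read-out higher numbers stand for weaker inhibition and lower numbers for stronger inhibition), compound 1 gives 4500 nM, the only numerical reading in the set. Compound 2 `CO[C@H](C(=O)NS(=O)(=O)OC[C@H]1O[C@@H](n2cnc3c(N)nc(Cl)nc32)[C@H](O)[C@@H]1O)[C@H](OC)C(C)C` carries two methoxy groups on the acyl chain and a chlorine on the core; in this assay compound 2 returns only a limit, > 20000 nM. Compound 3 `CC(C)[C@@H](O)[C@H](O)C(=O)NS(=O)(=O)OC[C@H]1O[C@@H](n2cnc3c(=O)[nH]cnc32)[C@H](O)[C@@H]1O` carries a 1,2-dihydroxy acyl chain on a core with a ring carbonyl and a ring amide hydrogen in place of the amine of compound 1; in this assay compound 3 also returns only a limit, > 20000 nM. Compound 3 therefore stands at the floor of what the assay reports, together with compound 2 (the limit of > 20000 nM in this assay, at which 2 of the 3 values shown sit), with no number of its own to compare against compound 1.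

Compound 4 `CC(C)C[C@H](O)C(=O)NS(=O)(=O)OC[C@H]1O[C@@H](n2cnc3c(=O)[nH]cnc32)[C@H](O)[C@@H]1O` keeps the core of compound 3 and the acyl chain of compound 1. Relative to compound 3 the change is hydrogen in place of hydroxy on a saturated chain carbon bound to two saturated chain carbons. Going by the values given here, no measured pair spans this change alone, so the step has to be guessed. With compound 3 at the limit, the step from compound 3 to compound 4 in this assay is expected to be a number no higher from compound 3 to compound 4 (the limit leaves the size open), that is, little movement beyond the scatter, and most likely a limit again. Compound 4 is expected to give about 20000 nM, within 6000 nM to 60000 nM.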

Compound 4, half-maximal inhibitory concentration: > 20000 nM
Compound 4 was reported as a limit (the forecaster's own chance of this, stated with the estimate: 65%); the middle value sits exactly at the limit.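

For the compounds shown here, with the acyl chain held, the exchange at the saturated ring carbon of the core alone, from the form bearing the amine to the form with a ring carbonyl and the amide hydrogen, gives an at least 4.4-fold higher number from compound 1 to compound 4 (0.64 log units; beyond the scatter); this is the first readable single-place step, and it lies beyond the scatter. In this assay compound 4 gives > 20000 nM, which is a limit, so hydrogen in place of hydroxy on a saturated chain carbon bound to two saturated chain carbons yields no numerical reading on this core, and the step between the two limits cannot be read. The limit now holds most of the series: the limit of > 20000 nM in this assay, at which 3 of the 4 values shown sit.

The compounds shown do not place the 1-hydroxy-2-methylpropyl chain on the core of compound 1, so what that hydroxy does on a core giving a numerical reading remains open. Also open, from the compounds shown here alone, is how an amine in place of that hydroxy, or a longer chain in place of isobutyl, would read on the core of compound 1.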